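Ring nitrogen substituents in a cytotoxicity series

This account rests on a few compounds, and the source may have more. Where it says the series, first, only, none or still open, it means among the compounds named here.

Values in a functional assay on DU-145 cells (Homo sapiens) for cytotoxicity, read by sulforhodamine B assay, with a stated time of 48 h; on this read-out lower numbers stand for higher toxicity in this test and higher numbers for lower toxicity in this test; every value so far is a limit of the assay, not a number:
compound 1 `N#Cc1ccc(Nc2nc(Oc3ccnc4ccccc34)nc(N3CCN(c4cccc(C(F)(F)F)c4)CC3)n2)cc1C(F)(F)F`: > 100000 nM
compound 2 `N#Cc1ccc(Nc2nc(Oc3ccnc4ccccc34)nc(N3CCN(C(c4ccccc4)c4ccccc4)CC3)n2)cc1C(F)(F)F`: > 100000 nM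
compound 3 `N#Cc1ccc(Nc2nc(Oc3ccnc4ccccc34)nc(N3CCN(c4ncccn4)CC3)n2)cc1C(F)(F)F`: > 100000 nM

Compound 3 therefore stands only at a limit in this assay, and the two other values are limits as well (the limit of > 100000 nM in this assay, at which 3 of the 3 values shown sit). Within the data shown here, the one change between measured compounds that differs in a single place, from compound 1 to compound 3, gives a step that the two limits leave unreadable from compound 1 to compound 3; with both ends at the limit, its size cannot be read. Compound 4 `N#Cc1ccc(Nc2nc(Oc3ccnc4ccccc34)nc(N3CCN(Cc4ccccc4)CC3)n2)cc1C(F)(F)F` is the next compound to be measured. It differs from compound 3 in one place: benzyl in place of pyrimidin-2-yl on an amine nitrogen in a ring. Among the measured compounds shown here, no measured step bears readably on this change, and nothing among compounds 1, 2 and 3 separates one substituent on the ring nitrogen from another in this assay. For compound 4 the expectation is therefore a step that the limit leaves unreadable from compound 3 to compound 4, that is none beyond the scatter, with the most likely outcome again a limit. The estimate for compound 4 in this assay is 150000 nM, within 50000 nM to 500000 nM.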

Compound 4, concentration lethal to 50% of the cells: > 100000 nM
Compound 4 ended at the assay's limit (the forecaster's own chance of this, stated with the estimate: 85%); the middle value lies beyond the limit too.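

The steps among compound 1, compound 2, compound 3 and compound 4 cannot be read, as each compound stands only at a limit in this assay: the limit of > 100000 nM in this assay, at which 4 of the 4 values shown sit.

The compounds shown leave open whether any substituent on the amine nitrogen in the ring gives a readable number in this assay.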